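Estimating clearance for a pyridine analogue of compound 2

The compounds below may be only part of what the source reports. "The series", "measured", "known", "first", "only" and "open" are said of these compounds alone.

Compound 1 (`CCCOc1cc([C@](O)(CCN(C)C)[C@@H](c2cc3cc(Br)ccc3nc2OC)c2ccnc(OC)c2OC)cc(OC)n1`): 6.9 mL/min/kg
Compound 2 (`COc1cc([C@](O)(CCN(C)C)[C@@H](c2cc3cc(Br)ccc3nc2OC)c2cccc(OC)c2F)cc(OC(F)F)n1`): 9.7 mL/min/kg

Both numbers come from an ADME assay on the whole organism (Mus musculus, strain CD-1) for pharmacokinetics; a higher number here means faster removal of the compound, a lower number slower removal. Compound 2 gives the value shown above, and it lies within the usual scatter of the value for compound 1, so these two numbers cannot be told apart with any confidence.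

The next molecule is compound 3 (`COc1cc([C@](O)(CCN(C)C)[C@@H](c2cc3cc(Br)ccc3nc2OC)c2ccnc(OC)c2OC)cc(OC(F)F)n1`), which has not yet been measured. It differs from compound 2 by one swap, 2,3-dimethoxypyridin-4-yl in place of 2-fluoro-3-methoxyphenyl on a saturated chain carbon bound to an aromatic carbon and a saturated chain carbon.

Among the measured compounds shown here, no measured pair shows what a single change does here, so the data offer no direct guide to this swap. The expectation rests only on the general level set by compound 1 at 6.9 mL/min/kg and compound 2 at 9.7 mL/min/kg in this series. The expected 1.2-fold lower number from compound 2 to compound 3 (0.08 log units; within the scatter) is therefore no step beyond the scatter, in either direction. In this assay compound 3 is estimated at 8 mL/min/kg, with an expected range from 4.5 mL/min/kg to 15 mL/min/kg.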

Compound 3, clearance: 8.7 mL/min/kg
For compound 3 the middle estimate is 1.1-fold (0.04 log units) below the measured one; the measured number falls inside the stated range.
By their numbers in this assay, from the lowest: compounds 1, 3 and 2 (each within the scatter of the next).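

In this assay this series now has its first comparisons of compounds that differ in one place. Putting 2,3-dimethoxypyridin-4-yl in place of 2-fluoro-3-methoxyphenyl on the saturated chain carbon gives a step within the scatter (a 1.1-fold lower number from compound 2 to compound 3 (0.05 log units; within the scatter)), and the same holds for difluoromethyl in place of propyl on an oxygen on an aromatic ring (a 1.3-fold higher number from compound 1 to compound 3 (0.10 log units; within the scatter)), so neither change can be told apart from repeat-measurement noise in how fast the mouse removes these compounds. Nothing measured here explains why these two swaps leave the numbers so close.

These three compounds leave open whether any group at either place would give a step beyond the scatter, for instance an amine or a carboxylic acid in place of the aromatic ring on the chain carbon, or a longer chain such as butyl on the oxygen. They also cannot show whether the two swaps would give similarly small steps on a different core, since all three compounds share one.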